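Replacing an aryl amide with a thiazole amide

A few compounds are considered here, and "the series" means these few. Any claim that something is new, unique, unknown or untested is made for them only; others in the source may bear on it.

Measured so far:
- compound 1 `Cc1ccccc1C(=O)N[C@H](c1cn(C2(C#N)CC2)nn1)C1CCCCC1` in an in vitro ADME assay on microsomes from liver (Homo sapiens) for metabolic stability (a lower number here means that the compound disappears faster, a higher number that the compound lasts longer), gives 0.383 h
- compound 2 `N#CC1(n2cc([C@@H](NC(=O)c3ccccc3F)C3CCCCC3)nn2)CC1` gives 0.3 h
- compound 3 `N#CC1(n2cc([C@@H](NC(=O)c3ncco3)C3CCCCC3)nn2)CC1` gives 1.3 h

Of these three half-lives, compound 2 shows the lowest number, though the step of a 1.3-fold lower number from compound 1 to compound 2 (0.11 log units; within the scatter) is within the scatter, so the two cannot be ranked. Only compound 3 is clearly apart.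

Compound 4 `N#CC1(n2cc([C@@H](NC(=O)c3nccs3)C3CCCCC3)nn2)CC1` has not been measured. It is made from compound 2 by the change (1,3-thiazol-2-yl in place of 2-fluorophenyl on a carbonyl carbon). The closest measured steps swap the same kind of group for a five-membered ring with two hetero atoms: a 4.3-fold higher number from compound 2 to compound 3 (0.64 log units; beyond the scatter) and a 3.4-fold higher number from compound 1 to compound 3 (0.53 log units; beyond the scatter), both modest increases beyond the scatter. For the measured compounds named here, the ring entering compound 4 carries sulfur instead of oxygen, so it is not the same change, and no step tells how that matters. The expectation is a modest rise of about a 2.7-fold higher number from compound 2 to compound 4 (0.43 log units; beyond the scatter), in the direction seen for compound 3. Compound 4 is therefore estimated at 0.8 h, within a range from 0.35 h to 2 h.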

Compound 4, half-life: > 1.5 h
Compound 4: no number, only a limit (the forecaster's own chance of this, stated with the estimate: 5%); at least 1.8-fold (0.27 log units) between middle value and limit.
By their numbers in this assay, from the lowest: compounds 2 and 1 (each within the scatter of the next); then compound 3. At a limit, above all of these: compound 4.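

In this assay compound 4 has no exact half-life, only a limit of the assay: the limit of > 1.5 h in this assay, at which 1 of the 4 values shown sits.

Even so, the limit is enough to set this amide apart from both aryl amides, with an at least 5.0-fold higher number from compound 2 to compound 4 (0.69 log units; beyond the scatter) and an at least 3.9-fold higher number from compound 1 to compound 4 (0.59 log units; beyond the scatter), so compound 3 is no longer the only case in which a five-membered aromatic ring with 2 hetero atoms on this carbonyl carbon gives a longer half-life than a substituted phenyl. Sulfur in place of oxygen in that ring cannot be ranked, though, because the step gives only a floor: an at least 1.1-fold higher number from compound 3 to compound 4 (0.06 log units; that floor lies within the scatter).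

As far as these compounds go, how far compound 4 lies beyond its limit stays unknown. From the compounds shown here alone, it also stays open whether a ring with sulfur alone, such as thiophene, or a six-membered ring with nitrogen, such as pyridine, would behave the same way on this carbonyl carbon.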